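Varying the aryl group: estimating a 4-acetylphenyl analogue

A few compounds are considered here, and "the series" means these few. Any claim that something is new, unique, unknown or untested is made for them only; others in the source may bear on it.

Compound 1 `c1ccc(-c2cn3ccnc3c(-c3ccc4ncn(C5CCCCC5)c4c3)n2)cc1`: -11.1%
Compound 2 `c1ccc2c(-c3cn4ccnc4c(-c4ccc5ncn(C6CCCCC6)c5c4)n3)cccc2c1`: 41.3%
Compound 3 `Fc1ccc(-c2cn3ccnc3c(-c3ccc4ncn(C5CCCCC5)c4c3)n2)cc1`: 33.3%

Of the compounds shown here, three sharing one core have been measured in a functional assay on T47D cells (Homo sapiens) for inhibition, read by sulforhodamine B assay, with a stated time of 48 h, tested at 10 uM; on this read-out lower numbers stand for less inhibition and higher numbers for more inhibition at the one concentration tested (going by the name of the read-out). Compound 2 carries the naphthalen-1-yl group and stands highest of the three numbers; its nearest neighbour is compound 3, which sits a number 8 percentage points lower from compound 2 to compound 3 (within the scatter), a gap that does not separate the two. Compound 1, with a plain phenyl, lies furthest away: the step of a number 52.4 percentage points higher from compound 1 to compound 2 (beyond the scatter) is large, as is the step of a number 44.4 percentage points higher from compound 1 to compound 3 (beyond the scatter).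

Compound 4 `CC(=O)c1ccc(-c2cn3ccnc3c(-c3ccc4ncn(C5CCCCC5)c4c3)n2)cc1` is not yet measured. Relative to compound 2 the change is 4-acetylphenyl in place of naphthalen-1-yl on an aromatic carbon. Among the compounds with values here, no measured step replaces naphthalen-1-yl with an acetyl-bearing phenyl, so the nearest guide is the step from compound 2 to compound 3, which also exchanges naphthalen-1-yl for a phenyl bearing one group and stayed within the scatter, together with the large gain seen from compound 1 to compound 3 on adding a single group to the phenyl. On that basis compound 4 is expected to land somewhat below compound 2, with the step of a number 13.3 percentage points lower from compound 2 to compound 4 (beyond the scatter) estimated as modest, possibly within the scatter. The estimate for compound 4 in this assay is 28%, with a range from -5% to 55%.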

Compound 4, a percentage reported as inhibition, at one concentration (the size of the read-out at that concentration, not a potency): 54.4%
The estimate for compound 4 lay 26.4 percentage points below the measured number; measured number inside the range.
By their numbers in this assay, from the lowest: compound 1; then compounds 3 and 2 (each within the scatter of the next); then compound 4.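

In this assay, within the data shown here, the 4-acetylphenyl group is the first at this position to separate from the other substituted aryl groups, with a number 13.1 percentage points higher from compound 2 to compound 4 (beyond the scatter) and a number 21.1 percentage points higher from compound 3 to compound 4 (beyond the scatter), whereas the naphthalen-1-yl and 4-fluorophenyl groups could not be told apart. Set against the plain phenyl, acetyl gives a number 65.5 percentage points higher from compound 1 to compound 4 (beyond the scatter), so a single group on the phenyl ring can take the number past that of the naphthalen-1-yl compound, and the second aromatic ring of naphthalen-1-yl is not needed to reach this level of inhibition. Nothing available here shows what lies behind the gain from the acetyl group.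

The compounds shown leave open whether the carbonyl itself matters or any group of similar size at that place on the phenyl ring would do as well, which a methyl ketone's close relatives, such as a primary amide, a carboxylic acid or a hydroxyethyl group, could test. They also leave open whether the order seen in this assay at one concentration would hold as a matter of potency.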